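The source may hold more compounds than are shown below. What is called first, only, known or untested is meant among the compounds shown, and "the series" means these compounds.

Measured compounds:
- compound 2, `COc1cc(/C=C/C(=O)c2ccc(O)cc2O)cc(OC)c1OC`: in a functional assay on MCF7 cells (Homo sapiens) for inhibition, read by sulforhodamine B assay, with a stated time of 48 h (on this read-out higher numbers stand for weaker inhibition of growth and lower numbers for stronger inhibition of growth), compound 2 gives 7800 nM
- compound 3, `COc1ccc(/C=C/C(=O)c2ccc(O)cc2O)c(OC)c1`: in this assay compound 3 gives 19500 nM
- compound 1, `COCOc1cc(O)ccc1/C=C/C(=O)c1ccc(O)cc1O`: in this assay compound 1 gives "not determined" (no result reported)

Of the two compounds with a number, compound 3 has the higher one, so it is the weaker inhibitor of growth; compound 2 sits at a lower number, and the gap between them is larger than the scatter of the method. Compound 4, `COc1cc(OC)c(OC)cc1/C=C/C(=O)c1ccc(O)cc1O`, keeps the whole of compound 3 and changes one point: methoxy in place of hydrogen on an aromatic carbon. Among the measured compounds shown here, since no pair of measured compounds differs in exactly this way, no measured step tells what such a change does here. For the measured compounds named here, the two numbers known suggest that a third methoxy on that ring can go with a lower number, as in compound 2, though its methoxy groups sit elsewhere. A moderate move toward stronger inhibition is therefore expected, as the step of a 2.0-fold lower number from compound 3 to compound 4 (0.29 log units; within the scatter) in this assay. Compound 4 is estimated at 10000 nM, within a range from 4000 nM to 25000 nM.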

Compound 4, concentration for 50% growth inhibition: 31800 nM
For compound 4 the middle estimate is 3.2-fold (0.50 log units) below the measured one, and the stated range ends below it.
By their numbers in this assay, from the lowest: compound 2; then compounds 3 and 4 (each within the scatter of the next).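

In this assay, among the compounds shown here, the first measured step at this position, methoxy in place of hydrogen on an aromatic carbon that is ortho to a methoxy group, para to a methoxy group and meta to a large group, is a 1.6-fold higher number from compound 3 to compound 4 (0.21 log units; within the scatter) and so cannot be told apart from no change. At this carbon, then, a third methoxy on the ring does not bring a lower number, and the added group is accepted without a readable gain or loss in growth inhibition. Nothing at hand explains this outcome.

On these data alone, whether the same carbon would respond differently to a smaller atom such as fluorine or chlorine, or to an amine or a carboxylic acid, stays open. Also open, as far as these compounds go, is whether a longer chain such as ethoxy would leave the number just as unmoved.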